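A few compounds are considered here, and "the series" means these few. Any claim that something is new, unique, unknown or untested is made for them only; others in the source may bear on it.

Measured so far:
- compound 1 `Cc1cccc(-c2nc3cc(C)ccc3c(=O)[nH]2)c1`: 21100 nM
- compound 2 `Cc1ccc2nc(-c3ccccc3C)[nH]c(=O)c2c1`: 11700 nM
- compound 3 `Cc1ccc2nc(-c3ccccc3F)[nH]c(=O)c2c1`: > 50000 nM (a limit of the assay, not a number)

All values come from a functional assay on HCT-15 cells (Homo sapiens) for cytotoxicity, read by MTT assay, with a stated time of 2 days; a higher number here means a weaker inhibitor, a lower number a stronger inhibitor. Compound 1 gives 21100 nM and compound 2 gives 11700 nM; the two lie within the scatter of each other, so no order between them is claimed. Compound 1 and compound 2 are built from the same atoms joined differently; the difference between the two cores is not broken down here.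

For compound 3 the assay reports only a limit, > 50000 nM. The step of an at least 4.2-fold higher number from compound 2 to compound 3 (0.63 log units; beyond the scatter) is therefore known only as a lower bound, since it runs into (the limit of > 50000 nM in this assay, at which 1 of the 3 values shown sits). The change behind it is fluoro in place of methyl on an aromatic carbon

Compound 4 `Cc1ccc2c(=O)[nH]c(-c3cccc(F)c3)nc2c1` has not yet been measured in this assay. It differs from compound 1 by fluoro in place of methyl on an aromatic carbon

This is the same kind of change as that from compound 2 to compound 3, not the same change: there the fluoro stands ortho to a large group, here meta to a large group. For the measured compounds named here, only one measured example of the change exists, so the carry-over to a different place is uncertain.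

For compound 4 the expected step is a 2.8-fold higher number from compound 1 to compound 4 (0.45 log units; beyond the scatter). This expectation rests on the step of an at least 4.2-fold higher number from compound 2 to compound 3 (0.63 log units; beyond the scatter) and on the value of compound 1, 21100 nM. Compound 4 is estimated at 60000 nM, with a range from 25000 nM to 150000 nM, and a limit rather than a number is quite possible.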

Compound 4, half-maximal inhibitory concentration: 14400 nM
Compound 4: middle estimate off by 4.2-fold (0.62 log units), on the high side; the whole stated range lies above it.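

In this assay, fluoro in place of methyl on an aromatic carbon does not carry over from one core to another as a fixed step, and the two examples differ: the same change on two cores in this assay, an at least 4.2-fold higher number (0.63 log units; beyond the scatter) from compound 2 to compound 3 and a 1.5-fold lower number (0.17 log units; within the scatter) from compound 1 to compound 4, at least 6.2-fold (0.79 log units) apart, beyond the scatter of two such steps

On the core of compound 1 the change gives a 1.5-fold lower number from compound 1 to compound 4 (0.17 log units; within the scatter), with the fluoro meta to a large group, whereas the other example has the fluoro at a different place on a different core, and a single pair on each core cannot separate the effect of the core from that of the place. The other step, an at least 4.2-fold higher number from compound 2 to compound 3 (0.63 log units; beyond the scatter), is only a lower bound, as compound 3 carries a limit of the assay and not a number, so its true size and the true gap between the two steps remain unknown: the limit of > 50000 nM in this assay, at which 1 of the 4 values shown sits.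

The compounds shown leave open whether the change would read the same on either core if the fluoro stood at the same place on both. They also leave open how other groups on the six-membered aromatic ring of carbon only, such as chloro, methoxy, an amine or a carboxylic acid, would read in this assay on these cores.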